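A few compounds are considered here, and "the series" means these few. Any claim that something is new, unique, unknown or untested is made for them only; others in the source may bear on it.

Compound 1 `CCOc1c(-c2occ(C)c2C(=O)O)ccc2c(CC)cccc12`: > 10 ug/mL
Compound 2 `CCOC(=O)c1c(C)coc1-c1ccc2c(CC)cccc2c1OC`: 2.2 ug/mL

Both compounds were tested in a functional assay on DU-145 cells (Homo sapiens) for cytotoxicity, read by MTT assay, with a stated time of 72 h; a lower number here means that less compound is needed, a higher number that more compound is needed for the effect. The result for compound 1 is a limit and not a number, > 10 ug/mL. Going by the values given here, compound 2 gives 2.2 ug/mL, which is the only actual number available, so it has no measured neighbour to be ranked against.

Compound 3 `CCc1cccc2c(OC)c(-c3occ(C)c3C(=O)On3nnc4ccccc43)ccc12` has yet to be measured in this assay. Its structure departs from that of compound 2 in one place: a group of 9 heavy atoms (6 carbon, 3 nitrogen; one five-membered aromatic ring with 3 hetero atoms, one six-membered aromatic ring of carbon only) in place of a group of 2 heavy atoms (2 carbon; no ring), on an oxygen next to a carbonyl group. An ethyl group thus gives way to a much larger group with two aromatic rings, on an oxygen next to a carbonyl group. Among the compounds with values here, no measured step between closely matched compounds shows what such a change does here, so the expectation rests on compound 2 and its 2.2 ug/mL. With so little to go on, no step beyond the usual scatter is expected in either direction. The expected change is a 1.4-fold higher number from compound 2 to compound 3 (0.13 log units; within the scatter). For compound 3 the estimate is 3 ug/mL, with an expected range from 1 ug/mL to 9 ug/mL.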

Compound 3, concentration for half-maximal effect: > 10 ug/mL
Compound 3: only a limit was reported; the forecaster's own chance of this, stated with the estimate: 15%; at least 3.3-fold (0.52 log units) between middle value and limit.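

Going by these compounds alone, this is the first measured step at this position: in this assay, ethyl on an oxygen next to a carbonyl group gives way to the much larger group with two aromatic rings, and the result is an at least 4.5-fold higher number from compound 2 to compound 3 (0.65 log units; beyond the scatter). The oxygen therefore does not accept every group without consequence, as this change moves the read-out beyond the usual scatter, and the direction is towards more compound being needed. Compound 3 gives only a limit, > 10 ug/mL, so the step has a floor but no measured size, and the top of the measurable range caps what can be read from it: the limit of > 10 ug/mL in this assay, at which 2 of the 3 values shown sit.

The compounds shown leave open whether the loss follows from the whole entering group or from one part of it, which a phenyl group or a benzyl group on the same oxygen would help to separate. They also leave open how far the chain on this oxygen can change before the value moves, as a methyl, propyl or tert-butyl group would show.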